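From 4-bromophenyl to 3-chlorophenyl on the sulfonamide

The source may report more compounds than this note shows. Statements on the series, on what has been measured and on what is new or still open speak of the compounds shown alone.

Compound 1 (`CCc1cccc(NS(=O)(=O)c2ccc(N3CCNC3=O)cc2)c1`) gives 130 nM
Compound 2 (`O=C1NCCN1c1ccc(S(=O)(=O)Nc2ccc(Br)cc2)cc1`) gives 240 nM

Going by the values given here, in a functional assay on MCF7 cells (Homo sapiens) for antiproliferative activity, read by sulforhodamine B assay, with a stated time of 48 h (a lower number here means a stronger inhibitor, a higher number a weaker inhibitor), compound 2 stands level with compound 1, the only other measured compound, and the gap between them is a 1.8-fold higher number from compound 1 to compound 2 (0.27 log units; within the scatter) on this scale. Compound 3 (`O=C1NCCN1c1ccc(S(=O)(=O)Nc2cccc(Cl)c2)cc1`) differs from compound 2 in one place (3-chlorophenyl in place of 4-bromophenyl on a sulfonamide nitrogen) with 3-chlorophenyl in place of 4-bromophenyl on a sulfonamide nitrogen. Among the compounds with values here, only one measured step bears on this, a change of group on that same nitrogen (a 1.8-fold higher number from compound 1 to compound 2 (0.27 log units; within the scatter)), so no step beyond the scatter is expected in this assay here. The expected step is a 1.3-fold lower number from compound 2 to compound 3 (0.12 log units; within the scatter) in size. Compound 3 is estimated at 180 nM with an expected range from 70 nM to 450 nM in this measurement.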

Compound 3, half-maximal inhibitory concentration: 79 nM
Beside the measured number, compound 3's estimate is 2.3-fold (0.36 log units) above it; the range from low to high includes it.
By their numbers in this assay, from the lowest: compounds 3, 1 and 2 (each within the scatter of the next, the first and the last beyond it).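

In this assay the sulfonamide nitrogen now shows a step beyond the scatter (a 3.0-fold lower number from compound 2 to compound 3 (0.48 log units; beyond the scatter)) with 3-chlorophenyl in place of 4-bromophenyl, whereas the earlier step there stayed within it. Chloro in place of ethyl on an aromatic carbon gives a step within the scatter (a 1.6-fold lower number from compound 1 to compound 3 (0.22 log units; within the scatter)). No measurement at hand explains these steps.

The compounds shown leave open whether the halogen or its position carries the larger step, a question that 3-bromophenyl or 4-chlorophenyl would address. As far as these compounds go, how an amine or a carboxylic acid on that ring would read also stays open.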